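A few compounds are considered here, and "the series" means these few. Any claim that something is new, unique, unknown or untested is made for them only; others in the source may bear on it.

Working notes on the series in a functional assay with Alpha-1A adrenergic receptor (Homo sapiens) as the target, read by calcium flux; a lower number here means a smaller maximal response, a higher number a larger maximal response. Compound 1 `c1ccc(-c2ccsc2)c(OCC2=NCCN2)c1` gives 98% in this assay. Compound 2 `c1ccc(-c2ccns2)c(OCC2=NCCN2)c1` gives 99% in this assay. Compound 3 `Cc1ccoc1-c1ccccc1OCC1=NCCN1` gives 99% in this assay. Compound 3 stands level with compound 2 at the digits shown, and the two together hold the highest of the three numbers; the furthest from compound 3 is compound 1, whose number is lower by an amount within the scatter. All steps among the measured compounds are small: a number 1 percentage points higher from compound 1 to compound 2 (within the scatter), a number 1 percentage points higher from compound 1 to compound 3 (within the scatter), no change at the digits printed from compound 2 to compound 3 (within the scatter).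

Compound 4 `Cc1csc(-c2ccccc2OCC2=NCCN2)n1` is not yet measured in this assay. It differs from compound 3 in one place: 4-methyl-1,3-thiazol-2-yl in place of 3-methylfuran-2-yl on an aromatic carbon. Within the data shown here, the steps that bear on this are the earlier exchanges of one five-membered aromatic ring for another on the same aromatic carbon, a number 1 percentage points higher from compound 1 to compound 2 (within the scatter) and no change at the digits printed from compound 2 to compound 3 (within the scatter), none of which moved the number beyond the scatter. The step of a number 1 percentage points lower from compound 3 to compound 4 (within the scatter) is therefore expected to stay within the scatter, in no particular direction. For compound 4 the value expected in this assay is 98%, with a range from 88% to 106%.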

Compound 4, largest response reached (reported as maximum), in percent of the reference or control that the assay uses: 104%
The estimate for compound 4 lay 6 percentage points below the measured number; the measured number falls inside the stated range.
By their numbers in this assay, from the lowest: compounds 1, 2, 3 and 4 (each within the scatter of the next).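

On this aromatic carbon of the shared core, the series in this assay now also includes a methyl-bearing five-membered aromatic ring with nitrogen and sulfur, the 4-methyl-1,3-thiazol-2-yl group. The exchange for 3-methylfuran-2-yl gives a number 5 percentage points higher from compound 3 to compound 4 (within the scatter) and the exchange for 1,2-thiazol-5-yl gives a number 5 percentage points higher from compound 2 to compound 4 (within the scatter) while the exchange for thiophen-3-yl gives a number 6 percentage points higher from compound 1 to compound 4 (within the scatter) so none of the three steps leaves the scatter. All four compounds therefore read as one level, and this change adds a hetero atom and a hydrogen-bond acceptor relative to 3-methylfuran-2-yl without a separable shift in maximal response.

From the compounds shown here alone, whether this level survives on this carbon with a group outside the five-membered aromatic rings, such as a primary amine, a carboxylic acid or a longer alkyl chain, stays open. Going by these compounds, what underlies the level response across these rings also stays open, with nothing available here that bears on it.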